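This account rests on a few compounds, and the source may have more. Where it says the series, first, only, none or still open, it means among the compounds named here.

Of the compounds shown here, two have so far been measured in a functional assay on HT-29 cells (Homo sapiens) for antiproliferative activity, read by MTT assay, with a stated time of 72 h; on this read-out higher numbers stand for weaker inhibition and lower numbers for stronger inhibition. Compound 1 `Cn1ccc2c(Oc3ccc(NC(=O)c4cc5cccnc5n(-c5ccccc5)c4=O)cc3F)ccnc21` gives 510 nM. Compound 2 `Cn1ccc2c(Oc3ccc(NC(=O)c4cc5cccnc5n(-c5ccc(Cl)cc5)c4=O)cc3F)ccnc21` gives 220 nM. Within the data shown here, the only step between them is a 2.3-fold lower number from compound 1 to compound 2 (0.37 log units; beyond the scatter). On these two numbers compound 2 stands lowest, with compound 1 its nearest neighbour.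

Compound 3 `COc1ccc(-n2c(=O)c(C(=O)Nc3ccc(Oc4ccnc5c4ccn5C)c(F)c3)cc3cccnc32)cc1` differs from compound 2 in one place: methoxy in place of chloro on an aromatic carbon. Among the measured compounds shown here, no measured step exchanges one substituent for another at this place; the single step from hydrogen to chloro bears on it only indirectly, showing that a group para to the large group shifts this assay by a modest amount. A methoxy group there is therefore expected to leave the number close to that of compound 2, with an expected step of a 1.4-fold higher number from compound 2 to compound 3 (0.13 log units; within the scatter) that may not exceed the scatter. Compound 3 is estimated at 300 nM, within the range 120 nM to 800 nM.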

Compound 3, half-maximal inhibitory concentration: 1290 nM
Compound 3: the middle estimate sits 4.3-fold (0.63 log units) below what was measured; the whole stated range lies below it.
By their numbers in this assay, from the lowest: compound 2; then compound 1; then compound 3.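

In this assay this position responds to which group is placed there, not merely to whether a group is present: there is a 5.9-fold higher number from compound 2 to compound 3 (0.77 log units; beyond the scatter), and against the unsubstituted ring there is a 2.5-fold higher number from compound 1 to compound 3 (0.40 log units; beyond the scatter). Chloro and methoxy therefore move the number in opposite directions from compound 1, and the exchange of one for the other is the largest step seen so far. Nothing measured here accounts for this split between the 4-chlorophenyl and 4-methoxyphenyl compounds.

The compounds shown leave open whether other groups at this place, such as fluoro, methyl or hydroxy, would fall on the side of chloro or of methoxy. They also leave open whether a longer ether such as ethoxy would raise the number further.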